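Cytotoxicity limits and one added methyl

This account rests on a few compounds, and the source may have more. Where it says the series, first, only, none or still open, it means among the compounds named here.

In an ADME assay on MT4 cells (Homo sapiens) for cytotoxicity, read by MTT assay, with a stated time of 4 days (on this read-out lower numbers stand for higher toxicity in this test and higher numbers for lower toxicity in this test), compound 1 (`CCN(C)c1nc(Cc2c(F)cccc2F)cc(=O)[nH]1`) gives > 89000 nM as a limit of the assay and not as a number. Compound 2 (`Cc1c(Cc2c(F)cccc2F)nc(N(C)C)[nH]c1=O`) gives > 89000 nM in this assay and this too is a limit. Compound 2 therefore stands without a number of its own, and the two measured compounds together show the limit of > 89000 nM in this assay, at which 2 of the 2 values shown sit, on this read-out.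

Compound 3 (`CCN(C)c1nc(Cc2c(F)cccc2F)c(C)c(=O)[nH]1`) has not been measured. Its difference from compound 2 is methyl in place of hydrogen on a saturated chain carbon bound to a nitrogen on an aromatic ring, so that dimethylamino becomes ethyl(methyl)amino. For the measured compounds named here, no measured step is available to size this change in this assay, so no step beyond the usual scatter is expected. The estimated step that the limit leaves unreadable from compound 2 to compound 3 is accordingly expected to be small and without a clear direction. For compound 3 the estimated value is 100000 nM with an expected range of 45000 nM to 200000 nM and another limit is the likeliest report.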

Compound 3, half-maximal cytotoxic concentration: > 85000 nM
Compound 3 was reported as a limit; the forecaster's own chance of this, stated with the estimate: 75%; the middle value is on the limit's open side.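

In this assay compound 3 gives > 85000 nM, which is a limit of the assay and not a number. For the compounds shown here, compound 1 and compound 2 also stand as limits, so no step to compound 3 can be read from either. The compounds shown leave open at what concentration any of the three becomes cytotoxic, and whether an added methyl changes that concentration.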